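Replacing a piperidine by a pyridinylamine on a shared core

This account rests on a few compounds, and the source may have more. Where it says the series, first, only, none or still open, it means among the compounds named here.

Compound 1 `CCOC(=O)c1c(N2CCCCC2)[nH]c2ccc(O)cc12` is the starting point. In an assay on isolated protein for inhibition of Polyunsaturated fatty acid 5-lipoxygenase (Homo sapiens), tested at 10 uM (a higher number here means more inhibition at the concentration tested (going by the name of the read-out), a lower number less inhibition), compound 1 gives "not determined" (no result reported), so it stands at no single number in this assay. Two close relatives carry a different group at the same place on the shared core. Compound 2 `CCOC(=O)c1c(N2CCN(c3ccccc3)CC2)[nH]c2ccc(O)cc12` gives 79% in this assay, and compound 3 `CCOC(=O)c1c(N2CCN(c3ccc(F)cc3)CC2)[nH]c2ccc(O)cc12` gives 81%. For the measured compounds named here, the one measured step, a number 2 percentage points higher from compound 2 to compound 3 (within the scatter), exchanges a hydrogen for a fluoro on an aromatic carbon and stays within the scatter.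

Compound 4 `CCOC(=O)c1c(Nc2cccnc2)[nH]c2ccc(O)cc12` differs from compound 1 in one place: (pyridin-3-yl)amino in place of piperidin-1-yl on an aromatic carbon. Going by the values given here, no measured step covers this kind of exchange, and the step from compound 2 to compound 3 concerns a hydrogen on a separate aromatic ring, so it offers no guidance on direction or size here. Among the compounds with values here, without a number for compound 1, the only anchors are compound 2 with 79% and compound 3 with 81%, both showing strong inhibition with a nitrogen-linked group at this place. Compound 4 is therefore expected to inhibit as well, though with much uncertainty, and its value in this assay is estimated at 60%, within a range from 25% to 90%.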

Compound 4, a percentage reported as inhibition, at one concentration (the size of the read-out at that concentration, not a potency): 24%
The estimate for compound 4 lay 36 percentage points above the measured number, and the stated range ends above it.
By their numbers in this assay, from the lowest: compound 4; then compounds 2 and 3 (each within the scatter of the next).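

Compound 1 has no number to set against compound 4 at 24%, so the exchange of piperidin-1-yl for (pyridin-3-yl)amino cannot be read as a step. The compounds shown leave open whether this exchange raises or lowers inhibition, and by how much. Nothing shown offers an explanation for the value of compound 4.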